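From compound 3 to compound 4: reworking a piperazine chain

A few compounds are considered here, and "the series" means these few. Any claim that something is new, unique, unknown or untested is made for them only; others in the source may bear on it.

Compound 1 `CN(C)CCCCCn1c2c(c3ccccc31)C(=O)c1c[n+]([O-])c3ccccc3c1C2=O` gives 370 nM
Compound 2 `O=C1c2c[n+]([O-])c3ccccc3c2C(=O)c2c1c1ccccc1n2CCCCn1ccnc1` gives 130 nM
Compound 3 `O=C1c2c[n+]([O-])c3ccccc3c2C(=O)c2c1c1ccccc1n2CCCCN1CCNCC1` gives 1240 nM

All three values come from a functional assay on SH-SY5Y cells (Homo sapiens) for cytotoxicity, read by MTT assay, with a stated time of 72 h (on this read-out lower numbers stand for stronger inhibition and higher numbers for weaker inhibition), and the compounds share one core, differing in the chain that carries a group at its end. Compound 3 has the highest number of the three (1240 nM) and so is the weakest inhibitor in this small set.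

Compound 4 `CN1CCN(CCCn2c3c(c4ccccc42)C(=O)c2c[n+]([O-])c4ccccc4c2C3=O)CC1` has the same atoms as compound 3, joined differently: 4-methylpiperazin-1-yl stands in place of (piperazin-1-yl)methyl on a saturated chain carbon, three bonds along the chain from an aromatic nitrogen (4-methylpiperazin-1-yl in place of (piperazin-1-yl)methyl on a saturated chain carbon, three bonds along the chain from an aromatic nitrogen). Put another way, 4-(piperazin-1-yl)butyl becomes 3-(4-methylpiperazin-1-yl)propyl.

Going by the values given here, two measured steps concern this chain: a 3.4-fold higher number from compound 1 to compound 3 (0.53 log units; beyond the scatter) and a 9.5-fold higher number from compound 2 to compound 3 (0.98 log units; beyond the scatter) are both beyond the usual scatter. Neither isolates the new methyl or the shorter chain, so they give only a rough scale. Both other chain ends measured so far sit lower than compound 3, which points to a modest downward move in this assay as the expectation. The expected change is a 1.9-fold lower number from compound 3 to compound 4 (0.28 log units; within the scatter) and it remains uncertain. Compound 4 is estimated at 650 nM with a range of 220 nM to 1900 nM expected.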

Compound 4, half-maximal inhibitory concentration: 560 nM
For compound 4 the middle estimate is 1.2-fold (0.06 log units) above the measured one; the measured number falls inside the stated range.
By their numbers in this assay, from the lowest: compound 2; then compounds 1 and 4 (each within the scatter of the next); then compound 3.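

In this assay the change from 4-(piperazin-1-yl)butyl to 3-(4-methylpiperazin-1-yl)propyl keeps the same atoms but joins them differently, and it gives a 2.2-fold lower number from compound 3 to compound 4 (0.35 log units; beyond the scatter) so rearranging this chain end alone can move the number by more than the usual scatter. The piperazine type of chain end also no longer stands apart from the dimethylamino chain end, as the comparison shows a difference of a 1.5-fold higher number from compound 1 to compound 4 (0.18 log units; within the scatter) while the 1H-imidazol-1-yl chain end keeps its lead, with a 4.3-fold higher number from compound 2 to compound 4 (0.63 log units; beyond the scatter) as the gap. Nothing measured here offers an explanation for these differences.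

As far as these compounds go, the new methyl and the shorter chain arrive together, so it remains open how much of the step belongs to each, a question that 3-(piperazin-1-yl)propyl or 4-(4-methylpiperazin-1-yl)butyl could help to separate. From the compounds shown here alone, it is also open whether the 1H-imidazol-1-yl group would hold its lead on a three-carbon propyl chain, and how a morpholine ring at the chain end would compare.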